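This account rests on a few compounds, and the source may have more. Where it says the series, first, only, none or still open, it means among the compounds named here.

Compound 1 `COc1ccc(-c2cc(/C=C/C(=O)c3ccc(N)cc3)[nH]n2)cc1` and compound 2 `COc1cc(-c2cc(/C=C/C(=O)c3ccc(Cl)c(Cl)c3)[nH]n2)cc(OC)c1OC` were both tested in a functional assay on UACC-257 cells (Homo sapiens) for cytotoxicity, read by sulforhodamine B assay, with a stated time of 48 h, tested at 1 uM; a higher number here means a weaker effect of the compound at the concentration tested, a lower number a stronger effect. In this assay compound 1 gives 90%, and compound 2 gives 90%, so compound 1 stands level with compound 2 within the scatter, and no ordering between them can be read. Compound 3 `COc1ccc(-c2cc(/C=C/C(=O)c3ccc(N)cc3)[nH]n2)cc1OC` differs from compound 1 by methoxy in place of hydrogen on an aromatic carbon, placed ortho to a methoxy group and meta to a large group. Among the compounds with values here, no step between measured compounds is available; since compound 2 carries three methoxy groups and still gives 90%, the expected step in this assay from compound 1 to compound 3 is none beyond the scatter, estimated as a number 1 percentage points lower from compound 1 to compound 3 (within the scatter). Compound 3 is therefore expected to give 89%, ranging from 75% to 100%.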

Compound 3, a percentage reported as activity, at one concentration (the size of the read-out at that concentration, not a potency): 96%
Compound 3: the middle estimate sits 7 percentage points below what was measured; the range from low to high includes it.
By their numbers in this assay, from the lowest: compounds 1, 2 and 3 (each within the scatter of the next).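

In this assay, within the data shown here, methoxy in place of hydrogen on this aromatic carbon, ortho to a methoxy group and meta to a large group, gives a number 6 percentage points higher from compound 1 to compound 3 (within the scatter), the first step in the set that can be read at a single place. At the one concentration tested, this position therefore shows no measurable response to the change. No available evidence bears on this result. Going by these compounds, whether a hydroxy group, a fluorine atom or an ethoxy chain on this carbon would also leave the read-out unchanged stays open.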